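This account rests on a few compounds, and the source may have more. Where it says the series, first, only, none or still open, it means among the compounds named here.

In an ADME assay on the whole organism for pharmacokinetics, with Mus musculus as the target, at a dose of 10 mg/kg by the oral route (on this read-out lower numbers stand for lower exposure and higher numbers for higher exposure at the dose given), three compounds have been measured so far:

Compound 1 `CC/C(=C(/c1ccc(/C=C/C(=O)O)cc1)c1ccc2[nH]ccc2c1)c1ccccc1` gives 9400 ng.h/mL
Compound 2 `CC/C(=C(/c1ccc(/C=C/C(=O)O)cc1)c1ccc2[nH]ncc2c1)c1ccccc1` gives 5800 ng.h/mL
Compound 3 `CC/C(=C(/c1ccc(/C=C/C(=O)O)cc1)c1ccc2[nH]ncc2c1)c1ccccc1Cl` gives 15000 ng.h/mL

Compound 3 at 15000 ng.h/mL lies within the scatter of compound 1 and clear of compound 2 (a 2.6-fold higher number from compound 2 to compound 3 (0.41 log units; beyond the scatter)). Compound 4 `CC/C(=C(/c1ccc(/C=C/C(=O)O)cc1)c1ccc2[nH]ncc2c1)c1cccc(Cl)c1` keeps the shared core and carries 3-chlorophenyl in place of 2-chlorophenyl on a double-bonded chain carbon bound to a double-bonded chain carbon and a saturated chain carbon. The closest evidence is the modest chloro step (a 2.6-fold higher number from compound 2 to compound 3 (0.41 log units; beyond the scatter)). The other measured step (a 1.6-fold lower number from compound 1 to compound 2 (0.21 log units; within the scatter)) concerns a different group and stays within the scatter. Going by the values given here, no measured pair sets 2-chlorophenyl against 3-chlorophenyl, so it is open how much of the chloro step carries over. A small drop that stays within the scatter is expected (a 1.5-fold lower number from compound 3 to compound 4 (0.18 log units; within the scatter)). For compound 4 the estimated value is 10000 ng.h/mL (expected range 4500 ng.h/mL to 20000 ng.h/mL).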

Compound 4, area under the concentration-time curve: 11000 ng.h/mL
Beside the measured number, compound 4's estimate is 1.1-fold (0.04 log units) below it, within the range that was stated.
By their numbers in this assay, from the lowest: compounds 2, 1, 4 and 3 (each within the scatter of the next, the first and the last beyond it).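

In this assay, putting 3-chlorophenyl in place of 2-chlorophenyl on a double-bonded chain carbon bound to a double-bonded chain carbon and a saturated chain carbon gives a small step (a 1.4-fold lower number from compound 3 to compound 4 (0.13 log units; within the scatter)), so these two chlorophenyl groups cannot be told apart on this read-out. Measured against compound 2, which has no chloro, 3-chlorophenyl stays within the scatter (a 1.9-fold higher number from compound 2 to compound 4 (0.28 log units; within the scatter)), whereas 2-chlorophenyl clears it (a 2.6-fold higher number from compound 2 to compound 3 (0.41 log units; beyond the scatter)), so the rise in exposure is secured only for 2-chlorophenyl. Nothing available here accounts for either step.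

On these data alone, whether these chloro steps would carry over to the core of compound 1 remains open. Also open, as far as these compounds go, is how a fluoro, a methoxy or an amine would compare with the chloro on this ring.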